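The source may hold more compounds than are shown below. What is called first, only, known or untested is meant among the compounds shown, and "the series" means these compounds.

Three compounds sharing one core were measured in an assay for displacement of a labelled ligand from E3 ubiquitin-protein ligase Mdm2 (Homo sapiens), read by fluorescence polarization, with a stated time of 30 min; a higher number here means a weaker inhibitor, a lower number a stronger inhibitor. Compound 1 `CC(C)Oc1ccc(-c2cc(C(=O)O)nn2-c2ccccc2)cc1` gives 2290 nM. Compound 2 `CC(C)COc1ccc(-c2cc(C(=O)O)nn2-c2ccccc2)cc1` gives 7420 nM, and compound 3 `O=C(O)c1cc(-c2ccc(OCc3ccccc3)cc2)n(-c2ccccc2)n1` gives 19800 nM. Every step among them concerns the group on the oxygen of the aromatic ring: a 3.2-fold higher number from compound 1 to compound 2 (0.51 log units; beyond the scatter), an 8.6-fold higher number from compound 1 to compound 3 (0.94 log units; beyond the scatter) and a 2.7-fold higher number from compound 2 to compound 3 (0.43 log units; beyond the scatter). Compound 3 therefore stands highest of the three numbers in this assay, with compound 2 nearest and compound 1 furthest away.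

Compound 4 `CC(C)c1ccc(-n2nc(C(=O)O)cc2-c2ccc(OCc3ccccc3)cc2)cc1` differs from compound 3 in another part of the molecule: isopropyl in place of hydrogen on an aromatic carbon. Among the measured compounds shown here, no measured step touches this ring; each of the three steps alters the group on the oxygen, so none of them bears directly on the change from compound 3 to compound 4. The data give no ground to expect a step in this assay beyond the scatter in either direction, and the estimate is kept close to the number of compound 3, with a wide range to reflect the absence of any bearing step. The expected step is a 1.3-fold lower number from compound 3 to compound 4 (0.12 log units; within the scatter). Compound 4 is estimated at 15000 nM in this assay, within a range from 4000 nM to 55000 nM.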

Compound 4, inhibition constant: 616 nM
For compound 4 the middle estimate is 24-fold (1.39 log units) above the measured one, outside the stated range (below it).
By their numbers in this assay, from the lowest: compound 4; then compound 1; then compound 2; then compound 3.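

Among the compounds shown here, the phenyl of the shared core, which none of the earlier steps touched, proves to be a position where a single change moves the number strongly: in this assay, going from phenyl to 4-isopropylphenyl gives a 32-fold lower number from compound 3 to compound 4 (1.51 log units; beyond the scatter). This one change, an isopropyl para to a large group, outweighs the largest step seen among the groups on the oxygen, an 8.6-fold higher number from compound 1 to compound 3 (0.94 log units; beyond the scatter), so the strength of binding in this series does not depend on the group on the oxygen alone. Nothing among the data shown offers an explanation for the size of this step.

The compounds shown leave open whether the same isopropyl would bring a step of similar size with an isopropyl or isobutyl on the oxygen, as in compound 1 or compound 2, rather than the benzyl of compound 3. They also leave open how smaller or larger groups at this place, such as a methyl, a tert-butyl or a chlorine, or an amine, would compare with the isopropyl.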